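Aryl swap on an aromatic nitrogen: antiproliferative read-out

The source may hold more compounds than are shown below. What is called first, only, known or untested is meant among the compounds shown, and "the series" means these compounds.

Three compounds of the series have been run in an ADME assay on L02 cells (Homo sapiens) for antiproliferative activity, read by MTT assay, with a stated time of 48 h; on this read-out higher numbers stand for weaker inhibition and lower numbers for stronger inhibition. Compound 1, `Cc1ccc(Cl)cc1-n1nncc1CN1C(=O)C2(C(C#N)=C(N)Oc3c2c2nc4ccccc4nc2c2ccccc32)c2ccccc21`, reaches only the limit of the assay: in this assay compound 1 gives > 50000 nM, a limit and not a number. Compound 2, `N#CC1=C(N)Oc2c(c3nc4ccccc4nc3c3ccccc23)C12C(=O)N(Cc1cnnn1-c1ccc(Cl)c(Cl)c1)c1ccccc12`, likewise ends at a limit, giving > 50000 nM in this assay. For the measured compounds named here, the one change between them, 3,4-dichlorophenyl in place of 5-chloro-2-methylphenyl on an aromatic nitrogen, gives a step that the two limits leave unreadable from compound 1 to compound 2, so no size can be read from it. Compound 3, `N#CC1=C(N)Oc2c(N)cc3nc4ccccc4nc3c2C12C(=O)N(Cc1cnnn1-c1ccc(Cl)cc1)c1ccccc12`, is the parent of the present step; in this assay compound 3 gives > 50000 nM, again a limit. All three values shown sit at that limit, as the limit of > 50000 nM in this assay, at which 3 of the 3 values shown sit, records, and compound 3 is therefore not separated from either of the others on the numbers shown.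

Compound 4 is `COc1ccc(OC)c(-n2nncc2CN2C(=O)C3(C(C#N)=C(N)Oc4c(N)cc5nc6ccccc6nc5c43)c3ccccc32)c1`. Relative to compound 3 the change is 2,5-dimethoxyphenyl in place of 4-chlorophenyl on an aromatic nitrogen. Going by the values given here, the only measured step, the one from compound 1 to compound 2, is unreadable, so it supplies no expected size for the present step in this assay in either direction, and nothing beyond the scatter is expected. The expectation for compound 4 is that it also sits at the limit: the estimate for compound 4 is 60000 nM, within 25000 nM to 200000 nM. The expected step is a step that the limit leaves unreadable from compound 3 to compound 4.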

Compound 4, half-maximal inhibitory concentration: > 50000 nM
Compound 4 was reported as a limit (the forecaster's own chance of this, stated with the estimate: 85%); the middle value is on the limit's open side.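

In this assay, compound 4 ends at a limit, as compound 3 does, so the step between compound 3 and compound 4 cannot be read: the limit of > 50000 nM in this assay, at which 4 of the 4 values shown sit. The compounds shown leave open how far these four differ in this assay, and whether any aryl group on the aromatic nitrogen gives a readable value there.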